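This account rests on a few compounds, and the source may have more. Where it says the series, first, only, none or still open, it means among the compounds named here.

Of the compounds shown here, three have been measured in a functional assay on the whole organism (strain Hartley) for inhibition, with Cavia porcellus as the target, with stated times of 15 min and 2 min (on this read-out higher numbers stand for an effect only at larger amounts of compound and lower numbers for an effect already at smaller amounts), so far.

compound 1 `CCCCC1([C@@H](O)/C=C/C2[C@H](O)CC(=O)[C@@H]2CCCCCCC(=O)O)CCC1` gives 0.017 mg/kg
compound 2 `CCCCC1([C@@H](O)/C=C/C2CCC(=O)[C@@H]2CCCCCCC(=O)O)CCC1` gives 0.0139 mg/kg
compound 3 `CCCCC1([C@H](O)/C=C/C2CCC(=O)[C@@H]2CCCCCC(=O)O)CCC1` gives 0.032 mg/kg

Compound 2 stands at the low end of these numbers together with compound 1, and compound 3 at 0.032 mg/kg lies clearly higher than both. The change under study leads to compound 4 `CCCCC1([C@@H](O)/C=C/C2CCC(=O)[C@@H]2CCCCCCC(=O)OCC)CCC1` and turns carboxy into ethoxycarbonyl, and ethyl in place of hydrogen on an oxygen next to a carbonyl group is the whole of the difference. For the measured compounds named here, no measured step touches this place. Going by the values given here, the only step available is a 1.2-fold lower number from compound 1 to compound 2 (0.09 log units; within the scatter) and it concerns a saturated ring carbon, so it shows merely that one change elsewhere left the number in place. Compound 3 differs from compound 2 in more than one place and cannot isolate any single change. No step beyond the scatter is therefore expected in this assay, although the data cannot exclude one and the range is kept wide. The expected step is a 1.4-fold higher number from compound 2 to compound 4 (0.16 log units; within the scatter) for this change. For compound 4 the estimated value is 0.02 mg/kg with an expected range from 0.006 mg/kg to 0.06 mg/kg in this read-out.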

Compound 4, dose for half-maximal effect: 0.032 mg/kg
Compound 4: middle estimate off by 1.6-fold (0.20 log units), on the low side, within the range that was stated.
By their numbers in this assay, from the lowest: compounds 2, 1, 3 and 4 (each within the scatter of the next, the first and the last beyond it).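

For the compounds shown here, the change from carboxy to ethoxycarbonyl gives the first measured step at this place: in this assay it produces a 2.3-fold higher number from compound 2 to compound 4 (0.36 log units; beyond the scatter). Ethyl in place of hydrogen on an oxygen next to a carbonyl group therefore moves the number beyond the scatter, though only modestly, and compound 4 still gives a measurable dose for half-maximal effect. Nothing in the data explains why the number moves with this change.

On these data alone, whether methyl or a longer alkyl chain on that oxygen, or an amide in place of the ester, would give a similar step remains open. Also open, as far as these compounds go, is whether ethoxycarbonyl would produce the same step on compound 1, which carries a hydroxy group on a saturated ring carbon.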